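This account rests on a few compounds, and the source may have more. Where it says the series, first, only, none or still open, it means among the compounds named here.

Compound 1 `CO[C@@H]1CC=C2NN(c3ccc(Cl)cc3)C(=O)C[C@]2(C)O1` was tested in a functional assay on A549 cells (Homo sapiens) for inhibition, read by sulforhodamine B assay, with a stated time of 48 h (a lower number here means a stronger inhibitor, a higher number a weaker inhibitor), and gave 25500 nM. Within the data shown here, the only other measured compound, compound 2 `COc1cc(OC)cc(N2NC3=CC[C@@H](OC)O[C@@]3(c3ccccc3)CC2=O)c1`, gave 17300 nM in this assay. Of these two numbers, compound 1 carries the higher one, yet the two values lie within the usual scatter of one another, so the data do not separate compound 1 from compound 2 in strength.

Compound 3 `CO[C@@H]1CC=C2NN(c3cncnc3)C(=O)C[C@]2(C)O1` has not yet been measured. It differs from compound 1 in one place: pyrimidin-5-yl in place of 4-chlorophenyl on an amide-type nitrogen in a ring. Among the measured compounds shown here, no step between two measured compounds describes this kind of swap, so nothing in the measured data says how large or in which direction the change should move the number.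

The expectation therefore rests on compound 1, which gave 25500 nM in this assay, and is for a small step, from compound 1 to compound 3 of about a 1.4-fold higher number from compound 1 to compound 3 (0.14 log units; within the scatter), not clearly beyond the scatter. On that basis compound 3 is expected to give roughly 35000 nM in this assay, with a likely range from 12000 nM to 110000 nM.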

Compound 3, half-maximal inhibitory concentration: 4100 nM
Estimate against measurement, compound 3: 8.5-fold (0.93 log units) above, outside the stated range (below it).
By their numbers in this assay, from the lowest: compound 3; then compounds 2 and 1 (each within the scatter of the next).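

At this amide-type nitrogen in a ring, the group carried matters in this assay: putting pyrimidin-5-yl in place of 4-chlorophenyl gives a 6.2-fold lower number from compound 1 to compound 3 (0.79 log units; beyond the scatter) on an otherwise unchanged core. The earlier compounds shown here could not show this, since the values of compound 1 and compound 2 lie within the scatter of each other and those two differ in more than one place. The swap changes several things at once, as the entering ring holds nitrogen and hydrogen-bond acceptors while the leaving ring holds carbon only and bears a chlorine, and nothing measured here gives a reason for the step.

From the compounds shown here alone, a plain phenyl group or a pyridin-3-yl group at this nitrogen would help to separate the loss of the chlorine from the gain of ring nitrogen, and where such compounds would fall relative to compound 1 and compound 3 stays open. Also open, going by these compounds, is whether the same swap gives a step of similar size when an ethyl group stands in place of the methyl group on the core.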